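Fluoro-methyl aryl terminus on the stilbene acid series

The source may hold more compounds than are shown below. What is called first, only, known or untested is meant among the compounds shown, and "the series" means these compounds.

Compound 1 `Cc1c(CCCC(=O)O)c2cccc(/C=C/c3ccc(OCCCCc4ccccc4)cc3)c2n1CC(=O)O` carries a plain phenyl at the end of the butoxy chain; in a functional assay on CHO-K1 cells for antagonist activity at cysteinyl leukotriene receptor 1 (Homo sapiens), read by fluorescence and calcium flux, with stated times of 30 min and 1 h (a higher number here means a weaker inhibitor, a lower number a stronger inhibitor), compound 1 gives 4.1 nM. Among the three measured compounds this is the second highest number: compound 3 `Cc1c(Cl)cccc1CCCCOc1ccc(C#Cc2cccc3c(CC(=O)O)c(C)n(CCCCC(=O)O)c23)cc1` gives 65 nM, a weaker result beyond the scatter, while compound 2 `Cc1c(Cl)cccc1CCCCOc1ccc(C#Cc2cccc3c(CCCC(=O)O)c(C)n(CC(=O)O)c23)cc1` gives 0.22 nM, stronger by a margin also beyond the scatter. Compound 2 differs from compound 1 in more than one place, so its gap to compound 1 is read only as two values, not as a single step.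

Compound 4 `Cc1c(F)cccc1CCCCOc1ccc(/C=C/c2cccc3c(CCCC(=O)O)c(C)n(CC(=O)O)c23)cc1` keeps the core and the alkene linker of compound 1 and changes only the chain terminus: 3-fluoro-2-methylphenyl in place of phenyl on a saturated chain carbon, four bonds along the chain from an oxygen on an aromatic ring. Among the compounds with values here, no measured pair isolates this change. Because compound 2 gives 0.22 nM with a closely related chloro-methyl aryl terminus, a step toward a lower number is expected, from compound 1 to compound 4 estimated at a 4.6-fold lower number from compound 1 to compound 4 (0.66 log units; beyond the scatter), beyond the scatter. Compound 4 is expected to give 0.9 nM, within 0.3 nM to 3 nM.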

Compound 4, half-maximal inhibitory concentration: 1.1 nM
The estimate for compound 4 lay 1.2-fold (0.09 log units) below the measured number, and the stated range covers the measured number.
By their numbers in this assay, from the lowest: compound 2; then compound 4; then compound 1; then compound 3.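

In this assay, within the data shown here, the change to 3-fluoro-2-methylphenyl in place of phenyl, on a saturated chain carbon, four bonds along the chain from an oxygen on an aromatic ring, gives a 3.7-fold lower number from compound 1 to compound 4 (0.57 log units; beyond the scatter) and is the first single-place step. It is a modest step, but it lies beyond the scatter. The chain terminus is thus a position where substitution on the phenyl moves the number while the core and the alkene linker stay fixed, and no data here give a reason for the step.

On these data alone, the fluorine and the methyl appear only together, so their separate contributions remain open. Also open, as far as these compounds go, is what another terminal group, such as trifluoromethyl or methoxy, or a longer chain in place of the butoxy chain would do.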